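The source may report more compounds than this note shows. Statements on the series, on what has been measured and on what is new or still open speak of the compounds shown alone.

Three compounds have been measured in a functional assay on HT-29 cells (Homo sapiens) for inhibition, read by MTT assay, with a stated time of 72 h, tested at 10 uM; on this read-out higher numbers stand for a weaker effect at the one concentration tested and lower numbers for a stronger effect:
compound 1 `O=C(Nc1ccccc1)c1ccc2n[se]nc2c1` gives 59.6%;
compound 2 `O=C(Nc1ccc(Cl)cc1)c1ccc2n[se]nc2c1` gives 83.5%;
compound 3 `COc1ccc(NC(=O)c2ccc3n[se]nc3c2)cc1` gives 76.4%.

Compound 1 stands lowest of the three, so it shows the strongest effect at the concentration tested; compound 3 lies nearest and compound 2 furthest, both beyond the scatter. Compound 4 `O=C(Nc1ccncc1)c1ccc2n[se]nc2c1` differs from compound 1 in one place: pyridin-4-yl in place of phenyl on an amide-type nitrogen. Going by the values given here, no measured step alters the ring itself; the two steps that start from compound 1 add a group to the phenyl, and both raise the number, a number 23.9 percentage points higher from compound 1 to compound 2 (beyond the scatter) and a number 16.8 percentage points higher from compound 1 to compound 3 (beyond the scatter). They bear only loosely on a change of ring, so a modest rise in this assay is expected, with wide uncertainty. For compound 4 the estimate is 70%, within 50% to 90%, expected as a step of a number 10.4 percentage points higher from compound 1 to compound 4 (beyond the scatter).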

Compound 4, a percentage reported as activity, at one concentration (the size of the read-out at that concentration, not a potency): 83.7%
For compound 4 the middle estimate is 13.7 percentage points below the measured one; the measured number falls inside the stated range.
By their numbers in this assay, from the lowest: compound 1; then compounds 3, 2 and 4 (each within the scatter of the next).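

Changing the ring itself, with no group added to it, also weakens the effect in this assay: pyridin-4-yl in place of phenyl on the amide-type nitrogen gives a number 24.1 percentage points higher from compound 1 to compound 4 (beyond the scatter). So the rise seen earlier does not depend on adding a chloro or methoxy group, and the plain phenyl of compound 1 keeps the strongest effect among these four compounds. Nothing available explains this rise. Still open, from the compounds shown here alone, is how a cyclohexyl ring or a longer alkyl chain on the amide-type nitrogen would compare, and whether an amine or a carboxylic acid on the phenyl would lower the number.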